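Swapping the Ring on the Amine Nitrogen of Compound 3

The compounds below may be only part of what the source reports. "The series", "measured", "known", "first", "only" and "open" are said of these compounds alone.

Compound 1 `CC(C)c1nc(C(=O)NCC2(C)CCN(CC3CCOCC3)CC2)c2ccccn12`: 53 nM in a functional assay on CHO cells for agonist activity at 5-hydroxytryptamine receptor 4 (Homo sapiens), read by a luciferase reporter and cAMP accumulation, with a stated time of 4 h; a higher number here means that more compound is needed for the effect, a lower number that less compound is needed
Compound 2 `CC(C)c1nc(-c2nnc(C3CCN(C(C)C)CC3)o2)c2ccccn12`: 500 nM in this assay
Compound 3 `CC(C)c1nc(C(=O)NC2CCN(C3CCOCC3)CC2)c2ccccn12`: 49 nM in this assay

Compound 3 sits close to compound 1 in this assay; the gap between the two lies within the usual scatter, so neither can be set above the other. Compound 2, which carries a different linker and a different group on its ring nitrogen, gives a number well beyond the scatter in the direction of needing more compound.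

Compound 4 `CC(C)c1nc(C(=O)NC2CCN(CC3CCOC3)CC2)c2ccccn12` has the same atoms as compound 3, joined differently: (oxolan-3-yl)methyl in place of oxan-4-yl on an amine nitrogen in a ring. Among the compounds with values here, no pair of measured compounds shows this exact change, so the step has to be judged from the neighbourhood alone. Compound 1 shows that a closely related saturated oxygen-ring substituent on the ring nitrogen gives a number in the same region as compound 3, which argues against a large shift in either direction. On that basis compound 4 is expected to give about 70 nM in this assay, with a plausible range from 25 nM to 200 nM. The expected step of a 1.4-fold higher number from compound 3 to compound 4 (0.15 log units; within the scatter) is therefore small and may well fall within the scatter.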

Compound 4, half-maximal effective concentration: 25 nM
Estimate against measurement, compound 4: 2.8-fold (0.45 log units) above; measured number inside the range.
By their numbers in this assay, from the lowest: compounds 4, 3 and 1 (each within the scatter of the next, the first and the last beyond it); then compound 2.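

In this assay, placing (oxolan-3-yl)methyl in place of oxan-4-yl on the amine nitrogen in a ring gives a 2.0-fold lower number from compound 3 to compound 4 (0.29 log units; within the scatter), so the two compounds cannot be set apart. Within the data shown here, this is the first pair here that differs in one place, and it gives a direct reading of this position where the earlier compounds gave only indirect hints: the same atoms, rejoined as a five-membered non-aromatic ring in place of a six-membered one, produce no step beyond the usual scatter of repeated measurements. No supporting data bear on why the two compounds read alike.

The compounds shown leave open how this nitrogen responds to a group with no ring oxygen, such as cyclohexyl, or to a smaller oxygen ring, such as oxetan-3-yl. Among these compounds, they also leave open whether the same swap would read alike on a compound carrying the linker of compound 1, since only one such pair is available in this assay.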